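Swapping Bromine for Fluorine on a Phenoxy Ring

This account rests on a few compounds, and the source may have more. Where it says the series, first, only, none or still open, it means among the compounds named here.

Four compounds share a bromo- or fluoro-substituted phenoxy group attached to a benzylidene hydrazone. Compound 1 `Brc1ccc(Oc2ccc(/C=N/Nc3nc4ccccc4s3)cc2)cc1` and compound 2 `Fc1ccc(Oc2ccc(/C=N/Nc3nc4ccccc4s3)cc2)cc1` carry a benzothiazole directly on the hydrazone nitrogen, while compound 3 `O=C(CSc1nc2ccccc2s1)N/N=C/c1ccc(Oc2ccc(Br)cc2)cc1` and compound 4 `O=C(CSc1nc2ccccc2s1)N/N=C/c1ccc(Oc2ccc(F)cc2)cc1` carry a longer arm in which the benzothiazole is linked through a thioether and an amide. How the two cores differ is not broken down here.

In a physicochemical assay for lipophilicity, in phosphate buffer, measured as octanol-water partition, with a stated time of 24 h (a lower number here means a more polar compound, a higher number a more lipophilic compound), compound 1 gives 5.5. Compound 2 gives 5. The change between them is fluoro in place of bromo on an aromatic carbon, and the measured step is a number 0.50 log units lower from compound 1 to compound 2 (beyond the scatter). Compound 3 gives 5.7, which lies within the scatter of compound 1 and stands above compound 2 by more than the scatter.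

Compound 4 has not yet been measured. Going by the values given here, it differs from compound 3 by fluoro in place of bromo on an aromatic carbon, which is the same change, at the same place, as the one between compound 1 and compound 2. The expectation is that the step from compound 3 to compound 4 will be about a number 0.50 log units lower from compound 3 to compound 4 (beyond the scatter), because the one measured case of this change gave a number 0.50 log units lower from compound 1 to compound 2 (beyond the scatter). For compound 4 the estimate in this assay is 5.2, expected to fall between 4.8 and 5.6. Among the compounds with values here, only one prior example supports this, so the actual result may differ.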

Compound 4, partition coefficient: 5.5
Compound 4: the middle estimate sits 0.30 log units below what was measured, and the stated range covers the measured number.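

On the second core, in this assay, fluoro in place of bromo gives a number 0.20 log units lower from compound 3 to compound 4 (within the scatter) and so cannot be told apart from repeat measurement, while the same change on the core of compound 1 gave a number 0.50 log units lower from compound 1 to compound 2 (beyond the scatter) and stood clear of that scatter. This shows that a step measured on one core did not carry over at full size to the other core in this pair of examples, so a single matched pair proved a weak guide here. It does not show that the core truly alters the effect of this change, since each core offers just one pair and each number carries its own scatter, and nothing available bears on why the two steps look different.

The compounds shown leave open how chloro, methyl or an amine in the place of the bromo would read in this assay on either core. They also leave open whether a third core, or a longer chain in the arm that holds the benzothiazole, would give a step closer to the first or to the second.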